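Moving the fluoromethyl group along the chain

The compounds below may be only part of what the source reports. "The series", "measured", "known", "first", "only" and "open" are said of these compounds alone.

In a functional assay on HL-60 cells (Homo sapiens) for cytotoxicity, read by WST assay, with a stated time of 48 h (on this read-out lower numbers stand for stronger inhibition and higher numbers for weaker inhibition), compound 3 (`COc1cc(C(c2ccc(O)c(OC)c2)[C@H](C)[C@H](C)CF)ccc1O`) gives 56000 nM and compound 2 (`COC[C@@H](C(C)C)C(c1ccc(O)c(OC)c1)c1ccc(O)c(OC)c1`) gives 54000 nM, two values within the scatter of each other. Compound 1 (`COc1cc(C(c2ccc(O)c(OC)c2)[C@H](C)[C@H](C)CO)ccc1O`) reads > 100000 nM, which is a limit of the assay and not a number.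

Compound 4 (`COc1cc(C(c2ccc(O)c(OC)c2)[C@@H](CF)C(C)C)ccc1O`) rearranges the chain of compound 3: 1-(fluoromethyl)-2-methylpropyl in place of 2-(fluoromethyl)-1-methylpropyl on a saturated chain carbon bound to two aromatic carbons. The entering 1-(fluoromethyl)-2-methylpropyl has the same chain form as the 1-(methoxymethyl)-2-methylpropyl of compound 2. The closest evidence is a 1.0-fold higher number from compound 2 to compound 3 (0.02 log units; within the scatter), which links the two chain forms. The other step, an at least 1.7-fold lower number from compound 1 to compound 3 (0.25 log units; that floor lies within the scatter), is only a floor. No step beyond the scatter is therefore expected in this assay.

The expected step is a 1.0-fold lower number from compound 3 to compound 4 (0.01 log units; within the scatter). Compound 4 is estimated at 55000 nM, with an expected range of 25000 nM to 100000 nM.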

Compound 4, half-maximal inhibitory concentration: 39000 nM
Estimate against measurement, compound 4: 1.4-fold (0.15 log units) above; low and high end bracket the measured number.
By their numbers in this assay, from the lowest: compounds 4, 2 and 3 (each within the scatter of the next). At a limit, above all of these: compound 1.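

In this assay the two chain forms carrying fluoromethyl read alike on the saturated chain carbon bound to two aromatic carbons, with a 1.4-fold lower number from compound 3 to compound 4 (0.16 log units; within the scatter) as the step between them. Fluoro and methoxy also read alike on this chain form, with a 1.4-fold lower number from compound 2 to compound 4 (0.14 log units; within the scatter) as the step. Among the compounds shown here, only the step of an at least 2.5-fold lower number from compound 1 to compound 4 (0.40 log units; beyond the scatter) lies beyond the scatter, and it is a floor set by a limit: the limit of > 100000 nM in this assay, at which 1 of the 4 values shown sits.

On these data alone, whether an amine or a carboxylic acid in place of the fluoro would read differently stays open. As far as these compounds go, a longer chain at this carbon also stays open.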